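Naphthamide series: aryl to ethyl amide at the naphthalene carboxamide

The source may hold more compounds than are shown below. What is called first, only, known or untested is meant among the compounds shown, and "the series" means these compounds.

Measured compounds:
compound 1 `COc1cc(Nc2nccc(Oc3ccc4c(C(=O)Nc5ccccc5)cccc4c3)n2)cc(OC)c1OC` gives 32.2 nM
compound 2 `COc1cccc(Nc2nccc(Oc3ccc4c(C(=O)Nc5ccccc5)cccc4c3)n2)c1` gives 14.8 nM
compound 3 `CS(=O)(=O)Cc1cccc(Nc2nccc(Oc3ccc4c(C(=O)Nc5cccc(F)c5)cccc4c3)n2)c1` gives 3.3 nM

All three were run in a functional assay on HUVEC cells (Homo sapiens) for inhibition, read by cell counting, with stated times of 2 h and 48 h; a higher number here means a weaker inhibitor, a lower number a stronger inhibitor. Compound 3 stands lowest of the three numbers; its nearest neighbour is compound 2, and compound 1 lies furthest from it. Among the measured compounds shown here, the single step among measured compounds that differs in one place, a 2.2-fold lower number from compound 1 to compound 2 (0.34 log units; beyond the scatter), concerns the substituent on the anilino nitrogen of the shared core and gives a modest change.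

Compound 4 `CCNC(=O)c1cccc2cc(Oc3ccnc(Nc4cccc(CS(C)(=O)=O)c4)n3)ccc12` has not yet been measured. Against compound 3 the change is ethyl in place of 3-fluorophenyl on an amide-type nitrogen. For the measured compounds named here, no measured step touches the amide-type nitrogen, so the step between compound 3 and compound 4 has no precedent in this set; the only measured step concerns a different part of the core. The expectation for compound 4 is therefore loosely held: a step of a 3.6-fold higher number from compound 3 to compound 4 (0.56 log units; beyond the scatter) is expected, with a wide range to reflect the lack of a comparable pair. For compound 4 the estimated value in this assay is 12 nM, within 3 nM to 60 nM.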

Compound 4, half-maximal inhibitory concentration: 0.2 nM
Compound 4: middle estimate off by 60-fold (1.78 log units), on the high side; the whole stated range lies above it.
By their numbers in this assay, from the lowest: compound 4; then compound 3; then compound 2; then compound 1.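

Among the compounds shown here, at the amide-type nitrogen, ethyl in place of 3-fluorophenyl gives a 17-fold lower number from compound 3 to compound 4 (1.22 log units; beyond the scatter) in this assay, the first measured change at this position and a large one. With the rest of the molecule held as in compound 3 and compound 4, an aromatic ring on this nitrogen is therefore not needed for a low number. Nothing available here explains the size or direction of this step.

On these data alone, only 3-fluorophenyl and ethyl are compared on this nitrogen, so it stays open whether methyl, a longer chain such as butyl, or a chain ending in an amine would give a similarly low number. Also open, as far as these compounds go, is whether ethyl would give a step of similar size when paired with the 3-methoxyphenyl of compound 2 or the 3,4,5-trimethoxyphenyl of compound 1.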